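The compounds below may be only part of what the source reports. "The series", "measured", "known", "first", "only" and "open" are said of these compounds alone.

Of the compounds shown here, three built on one shared core have been tested in a functional assay on RXF 393 cells (Homo sapiens) for inhibition, read by sulforhodamine B assay, with a stated time of 48 h, tested at 10 uM; on this read-out higher numbers stand for more inhibition at the one concentration tested (going by the name of the read-out) and lower numbers for less inhibition. Compound 1 `Brc1cn2ccnc2c(-c2ccc3ncn(C4CCCCC4)c3c2)n1` gives 5.58%. Compound 2 `Fc1ccc(-c2cn3ccnc3c(-c3ccc4ncn(C5CCCCC5)c4c3)n2)cc1` gives 24.4%. Compound 3 `c1cn2cc(-c3ccsc3)nc(-c3ccc4ncn(C5CCCCC5)c4c3)c2n1` gives 8.63%. On these three numbers compound 3 stands second highest; its nearest neighbour is compound 1, with a number 3.1 percentage points higher from compound 1 to compound 3 (within the scatter), and its furthest is compound 2, with a number 15.8 percentage points lower from compound 2 to compound 3 (beyond the scatter).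

Compound 4 `Fc1ccccc1-c1cn2ccnc2c(-c2ccc3ncn(C4CCCCC4)c3c2)n1` has not yet been measured. It differs from compound 3 in one place: 2-fluorophenyl in place of thiophen-3-yl on an aromatic carbon. Within the data shown here, two measured steps bear on this change. Replacing the bromo group by a six-membered fluorinated ring raised the number, as a number 18.8 percentage points higher from compound 1 to compound 2 (beyond the scatter), and going from that ring to thiophen-3-yl lowered it, as a number 15.8 percentage points lower from compound 2 to compound 3 (beyond the scatter). Among the measured compounds shown here, compound 4 carries a six-membered fluorinated ring again, but with the fluorine in a different place, and no measured pair shows what that placement does. A modest rise is therefore expected, a number 9.4 percentage points higher from compound 3 to compound 4 (within the scatter), with wide uncertainty. Compound 4 is estimated at 18%, ranging from 3% to 35%.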

Compound 4, a percentage reported as inhibition, at one concentration (the size of the read-out at that concentration, not a potency): 12.3%
Estimate against measurement, compound 4: 5.7 percentage points above; low and high end bracket the measured number.
By their numbers in this assay, from the lowest: compounds 1, 3 and 4 (each within the scatter of the next); then compound 2.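

In this assay the place of the fluorine on the phenyl ring matters, with a number 12.1 percentage points lower from compound 2 to compound 4 (beyond the scatter) when 2-fluorophenyl stands where 4-fluorophenyl stood, so a fluorinated six-membered ring at this position does not by itself give the higher number of compound 2. The 2-fluorophenyl group cannot be told apart from the two smaller groups, with a number 3.7 percentage points higher from compound 3 to compound 4 (within the scatter) against thiophen-3-yl and a number 6.7 percentage points higher from compound 1 to compound 4 (within the scatter) against bromo. Among these four compounds only the 4-fluorophenyl group stands clear of the others, and no measurement at hand explains this.

On these data alone, whether a plain phenyl ring, or a phenyl ring carrying an amine or a carboxylic acid, would match or pass compound 2 stays open. So does how any of these compounds behaves at other concentrations.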